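The source may hold more compounds than are shown below. What is called first, only, known or untested is meant among the compounds shown, and "the series" means these compounds.

Measured compounds:
- compound 1, `COc1ccc(-c2c(C)nn(-c3nc(-c4ccc(Cl)c(Cl)c4)c(SC(C)C)s3)c2C(=O)O)cc1`; in a functional assay on BJAB cells (Homo sapiens) for antiproliferative activity, with a stated time of 4 days (a lower number here means that less compound is needed, a higher number that more compound is needed for the effect), compound 1 gives 2100 nM
- compound 2, `Cc1nn(-c2nc(-c3ccc(Cl)c(Cl)c3)c(SC(C)C)s2)c(C(=O)O)c1-c1cccc(F)c1`; compound 2 gives 900 nM
- compound 3, `COc1cncc(-c2c(C)nn(-c3nc(-c4ccc(Cl)c(Cl)c4)c(SC(C)C)s3)c2C(=O)O)c1`; compound 3 gives 21000 nM

Compound 3 stands at the highest number of the three, needing the most compound for the effect. Its nearest neighbour is compound 1, with a 10-fold higher number from compound 1 to compound 3 (1.00 log units; beyond the scatter); its furthest is compound 2, with a 23-fold higher number from compound 2 to compound 3 (1.37 log units; beyond the scatter). Between the two phenyl analogues the step is a 2.3-fold lower number from compound 1 to compound 2 (0.37 log units; beyond the scatter).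

Compound 4, `Cc1nn(-c2nc(-c3ccc(Cl)c(Cl)c3)c(SC(C)C)s2)c(C(=O)O)c1-c1cncc(C#N)c1`, differs from compound 3 by cyano in place of methoxy on an aromatic carbon. Within the data shown here, none of the measured steps bears directly on this change: all three exchange the whole aromatic group rather than a substituent on a fixed ring, so they show only that changes at this position can move the number by a modest to large amount, with no direction given for a methoxy-to-cyano exchange on the pyridine. The expected step of a 1.4-fold lower number from compound 3 to compound 4 (0.15 log units; within the scatter) is therefore taken as none beyond the scatter, with wide uncertainty. In this assay compound 4 is expected at 15000 nM, with a range from 4000 nM to 60000 nM.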

Compound 4, half-maximal effective concentration: 20000 nM
Beside the measured number, compound 4's estimate is 1.3-fold (0.12 log units) below it, within the range that was stated.
By their numbers in this assay, from the lowest: compound 2; then compound 1; then compounds 4 and 3 (each within the scatter of the next).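

In this assay, among these compounds, the exchange of 5-methoxypyridin-3-yl for 5-cyanopyridin-3-yl gives a 1.1-fold lower number from compound 3 to compound 4 (0.02 log units; within the scatter) and so makes no difference beyond the scatter, the first reading of a substituent change on a fixed ring at this position. Compound 4 also stays well apart from the phenyl analogues, with a 22-fold higher number from compound 2 to compound 4 (1.35 log units; beyond the scatter) and a 9.5-fold higher number from compound 1 to compound 4 (0.98 log units; beyond the scatter), so among these four compounds both pyridinyl compounds need more compound for the effect than both phenyl compounds, with none going against this. No measurement at hand explains this gap or the flat step.

As far as these compounds go, whether the gap follows the ring nitrogen itself remains open, as a 3-cyanophenyl group would be needed to separate ring from substituent in this comparison. Also open, from the compounds shown here alone, is how an amine or a carboxamide on the same ring carbon would read.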